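This account rests on a few compounds, and the source may have more. Where it says the series, first, only, none or still open, it means among the compounds named here.

Measured so far in an assay on HeLa cells for inhibition of sphingosine-1-phosphate transporter SPNS2 (Mus musculus), read by LC-MS, tested at 2 uM; on this read-out higher numbers stand for more inhibition at the one concentration tested (going by the name of the read-out) and lower numbers for less inhibition:
- compound 1 `CCCCCCCCCCc1ccc(-c2noc(CC3CNC3)n2)cc1`: 63%
- compound 2 `CCCCCCCCCCc1ccc(-c2noc(-c3cccc(CN)c3)n2)cc1`: 2%
- compound 3 `CCCCCCCCCCc1ccc(-c2noc(CC[C@@H](N)C(=O)O)n2)cc1`: 5%

Compound 3 stands second highest of the three numbers, with compound 2 nearest and compound 1 far above it, shown by a number 58 percentage points lower from compound 1 to compound 3 (beyond the scatter). Compound 4 `CCCCCCCCCCc1ccc(-c2noc([C@@H](N)CCCCN)n2)cc1` differs from compound 3 in one place: 1,5-diaminopentyl in place of 3-amino-3-carboxypropyl on an aromatic carbon. Going by the values given here, no measured step swaps in this group, so the guidance is indirect. The step of a number 3 percentage points higher from compound 2 to compound 3 (within the scatter) shows that exchanging one amine-bearing group for another left the reading unchanged, while a number 61 percentage points lower from compound 1 to compound 2 (beyond the scatter) and a number 58 percentage points lower from compound 1 to compound 3 (beyond the scatter) show that the choice of group at this position can move the reading a long way. Compound 4 is therefore expected to rise only modestly, by a number 20 percentage points higher from compound 3 to compound 4 (beyond the scatter), and is estimated at 25% with a range from 2% to 65%.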

Compound 4, a percentage reported as inhibition, at one concentration (the size of the read-out at that concentration, not a potency): 43%
Compound 4: middle estimate off by 18 percentage points, on the low side; the measured number falls inside the stated range.
By their numbers in this assay, from the lowest: compounds 2 and 3 (each within the scatter of the next); then compound 4; then compound 1.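

In this assay, going by these compounds alone, the earlier compounds suggested that swapping one amine-bearing group for another changes little, but 1,5-diaminopentyl gives a number 38 percentage points higher from compound 3 to compound 4 (beyond the scatter) and a number 41 percentage points higher from compound 2 to compound 4 (beyond the scatter), so the kind of amine-bearing group at this position clearly matters. A group without a ring can therefore reach a high reading here, though it still falls short of the azetidine-bearing group, with a number 20 percentage points lower from compound 1 to compound 4 (beyond the scatter). Nothing available explains these differences.

From the compounds shown here alone, it remains open whether the gain depends on the second amine or on the chain itself. A chain ending in a hydroxyl group instead of that amine would separate the two.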